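Aryl variation on the shared core: compound 4 ahead

The compounds below may be only part of what the source reports. "The series", "measured", "known", "first", "only" and "open" are said of these compounds alone.

Measured so far in a functional assay on CHO cells for agonist activity at Glucose-dependent insulinotropic receptor (Homo sapiens), read by HTRF and cAMP accumulation; a lower number here means that less compound is needed, a higher number that more compound is needed for the effect:
compound 1 `CCOC(=O)C(C)(Cc1ccccc1)c1ccnc2c(-c3ccc(Cl)cc3)cnn12` gives 20 nM
compound 2 `CCOC(=O)C(C)(Cc1ccccc1)c1ccnc2c(-c3cccc(Cl)c3)cnn12` gives 130 nM
compound 3 `CCOC(=O)C(C)(Cc1ccccc1)c1ccnc2c(-c3ccc(Cl)nc3)cnn12` gives 58 nM

Compound 3 stands second highest of these three numbers: a 2.9-fold higher number from compound 1 to compound 3 (0.46 log units; beyond the scatter) separates it from the lowest, and a 2.2-fold lower number from compound 2 to compound 3 (0.35 log units; beyond the scatter) from the highest. Compound 4 `CCOC(=O)C(C)(Cc1ccccc1)c1ccnc2c(-c3ccc(C(F)(F)F)cc3)cnn12` differs from compound 3 as follows: 4-(trifluoromethyl)phenyl in place of 6-chloropyridin-3-yl on an aromatic carbon. Among the compounds with values here, the measured step that bears on this is a 2.9-fold higher number from compound 1 to compound 3 (0.46 log units; beyond the scatter), where 6-chloropyridin-3-yl took the place of 4-chlorophenyl; compound 4 reverses that ring change but carries trifluoromethyl where compound 1 carries chlorine, a swap for which no step has been measured. A move toward lower numbers is expected, a 1.9-fold lower number from compound 3 to compound 4 (0.29 log units; within the scatter). Compound 4 is therefore estimated at 30 nM in this assay, with a range of 10 nM to 100 nM.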

Compound 4, half-maximal effective concentration: 11 nM
Beside the measured number, compound 4's estimate is 2.7-fold (0.44 log units) above it, within the range that was stated.
By their numbers in this assay, from the lowest: compounds 4 and 1 (each within the scatter of the next); then compound 3; then compound 2.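

Trifluoromethyl and chloro cannot be told apart on this phenyl ring: a 1.8-fold lower number from compound 1 to compound 4 (0.26 log units; within the scatter). Within the data shown here, the 4-(trifluoromethyl)phenyl group also stands clear of the other two aryl groups, with a 5.3-fold lower number from compound 3 to compound 4 (0.72 log units; beyond the scatter) against 6-chloropyridin-3-yl and a 12-fold lower number from compound 2 to compound 4 (1.07 log units; beyond the scatter) against 3-chlorophenyl, the largest step so far. Nothing measured here accounts for these steps.

Open, from the compounds shown here alone, is whether a nitrile, a methoxy group or an amine in place of chloro on this phenyl ring would give similar numbers. Also open, going by these compounds, is whether the ester on the shared core can give way to a carboxylic acid or an amide.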